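This account rests on a few compounds, and the source may have more. Where it says the series, first, only, none or still open, it means among the compounds named here.

In a toxicity assay on Huh-7.5 cells (Homo sapiens) for inhibition, read by MTT assay, with a stated time of 96 h (a higher number here means that more compound is tolerated, a lower number that less compound is tolerated), compound 1 (`CN(C)C1CCN(Cc2ccc(NC(=O)c3ccc(OCCCCl)c([N+](=O)[O-])c3)cc2C(F)(F)F)C1`) gives 5800 nM, and compound 2 (`CC1CN(Cc2ccc(NC(=O)c3ccc(OCCCCl)c([N+](=O)[O-])c3)cc2C(F)(F)F)CC(C)O1`) gives 2300 nM. Among the measured compounds shown here, compound 2 therefore holds the lower of the two numbers so far. For the measured compounds named here, the only measured step, a 2.5-fold lower number from compound 1 to compound 2 (0.40 log units; beyond the scatter), is modest but beyond the scatter. It replaces 3-(dimethylamino)pyrrolidin-1-yl with 2,6-dimethylmorpholin-4-yl on a saturated chain carbon bound to an aromatic carbon.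

Compound 3 (`CN(C)C1CCN(Cc2ccc(NC(=O)c3ccc(OCCCCl)c([N+](=O)[O-])c3)cc2C(F)(F)F)CC1`) changes the same place, with 4-(dimethylamino)piperidin-1-yl in place of 2,6-dimethylmorpholin-4-yl on a saturated chain carbon bound to an aromatic carbon. Going by the values given here, this is the one measured step that bears on the change, and it offers only a single pair. Among the compounds with values here, no measured pair compares 3-(dimethylamino)pyrrolidin-1-yl directly with 4-(dimethylamino)piperidin-1-yl. The expectation rests on compound 1, which also carries a dimethylamino-bearing group and gives 5800 nM. A modest move back towards a higher number in this assay is therefore expected, of about the size of the measured step or slightly smaller. The expected change is a 2.2-fold higher number from compound 2 to compound 3 (0.34 log units; beyond the scatter). For compound 3 the estimated value is 5000 nM, with an expected range of 2200 nM to 11000 nM.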

Compound 3, half-maximal cytotoxic concentration: 5500 nM
For compound 3 the middle estimate is 1.1-fold (0.04 log units) below the measured one; the measured number falls inside the stated range.
By their numbers in this assay, from the lowest: compound 2; then compounds 3 and 1 (each within the scatter of the next).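

In this assay, placing 4-(dimethylamino)piperidin-1-yl on the saturated chain carbon bound to an aromatic carbon in place of 2,6-dimethylmorpholin-4-yl gives a 2.4-fold higher number from compound 2 to compound 3 (0.38 log units; beyond the scatter), so the difference first seen with compound 1 now recurs with a second dimethylamino-bearing group. Exchanging 3-(dimethylamino)pyrrolidin-1-yl for 4-(dimethylamino)piperidin-1-yl gives a 1.1-fold lower number from compound 1 to compound 3 (0.02 log units; within the scatter), which means this assay does not separate these two groups and compound 2 alone stands apart among the three compounds. Nothing measured alongside these numbers accounts for the separation of compound 2 from the other two compounds.

The compounds shown leave open whether the higher numbers go with the dimethylamino group itself or with the loss of 2,6-dimethylmorpholin-4-yl, a question that an unsubstituted piperidin-1-yl or a morpholin-4-yl without its two methyl groups would address. Also open, from the compounds shown here alone, is whether the same reading would extend to a primary amine such as 4-aminopiperidin-1-yl, or to a carboxylic acid carried on the piperidine ring at this place.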